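A few compounds are considered here, and "the series" means these few. Any claim that something is new, unique, unknown or untested is made for them only; others in the source may bear on it.

Measured compounds:
compound 1, `COc1ccc(C2=NN(C(=O)NS(=O)(=O)c3ccc(Cl)cc3)CC2c2ccccc2)c(OC)c1`, 25.7%
compound 2, `COc1ccc(C2=NN(C(=O)NS(=O)(=O)c3ccc(Cl)cc3)CC2C)c(OC)c1`, 16.5%
compound 3, `COc1ccc(C2=NN(C(=S)NC(=O)c3ccc(Cl)cc3)CC2C)c(OC)c1`, 1.94%

All three were tested in a functional assay on the whole organism (strain albino) for inhibition, with Rattus norvegicus as the target, read by paw edema, with stated times of 30 min and 3 h, at a dose of 25 mg/kg by the intraperitoneal route; a higher number here means more inhibition at the dose given (going by the name of the read-out), a lower number less inhibition. Compound 2 and compound 1 differ in one place, (phenyl in place of methyl on a saturated ring carbon), and the step is a number 9.2 percentage points higher from compound 2 to compound 1 (within the scatter). How the core of compound 3 differs from the core of compound 2 is not broken down here; compound 3 gives the lowest of the three numbers, and its gaps to compound 2 and compound 1 lie beyond the scatter.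

Compound 4, `COc1ccc(C2=NN(C(=S)NC(=O)c3ccc(Cl)cc3)CC2c2ccccc2)c(OC)c1`, is still unmeasured. It differs from compound 3 by phenyl in place of methyl on a saturated ring carbon, the same change as that from compound 2 to compound 1, at the same place. The expected step in this assay is a number 9.1 percentage points higher from compound 3 to compound 4 (within the scatter), which rests on the measured step of a number 9.2 percentage points higher from compound 2 to compound 1 (within the scatter) and on the small value of compound 3. Compound 4 is therefore expected to give 11%, likely between 0% and 25%.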

Compound 4, a percentage reported as inhibition, in the whole organism at one dose (the size of the read-out at that dose, not a potency): 1.43%
Compound 4: the middle estimate sits 9.6 percentage points above what was measured; the measured number falls inside the stated range.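

Putting phenyl in place of methyl on a saturated ring carbon gives, in this assay, a number 0.5 percentage points lower from compound 3 to compound 4 (within the scatter). Set beside the same change on the other core, this step does not stand apart: the same change on two cores in this assay, a number 9.2 percentage points higher (within the scatter) from compound 2 to compound 1 and a number 0.5 percentage points lower (within the scatter) from compound 3 to compound 4, 9.7 percentage points apart, within the scatter of two such steps. This gives no sign that the change behaves differently on the two cores, but it does not show that the change has a real effect on either one, and a single pair per core is thin evidence for how it carries over.

The compounds shown leave open what other groups on this ring carbon would give, such as a longer chain or a chain ending in an amine. They also leave open whether any such group would separate the two cores.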